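Removing the imidazolylmethyl group from compound 2

The source may report more compounds than this note shows. Statements on the series, on what has been measured and on what is new or still open speak of the compounds shown alone.

For the measured compounds named here, compound 2 `CCOC(=O)c1sc2ccc(NCc3nc[nH]c3C)cc2c1NC(=O)c1ccccc1` holds the highest of the three numbers so far in a functional assay on HeLa cells (Homo sapiens) for antiproliferative activity, read by MTT assay, with a stated time of 48 h (a higher number here means a weaker inhibitor of growth, a lower number a stronger inhibitor of growth), where compound 2 gives 23300 nM. Its nearest neighbour is compound 1 `CCOC(=O)c1sc2ccc(NCc3c[nH]cn3)cc2c1NC(=O)c1ccccc1`, which in this assay gives 17900 nM; the two lie within the scatter, as the step shows: a 1.3-fold higher number from compound 1 to compound 2 (0.11 log units; within the scatter). Furthest is compound 3 `CCOC(=O)c1sc2ccc(NCc3nc[nH]c3C)cc2c1NC(=O)c1ccc(F)c(Cl)c1`, which in this assay gives 2910 nM; that step is beyond the scatter: an 8.0-fold lower number from compound 2 to compound 3 (0.90 log units; beyond the scatter).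

Compound 4 `CCOC(=O)c1sc2ccc(N)cc2c1NC(=O)c1ccccc1` differs from compound 2 in one place: hydrogen in place of (5-methyl-1H-imidazol-4-yl)methyl on a nitrogen on an aromatic ring. Neither measured step touches this nitrogen. The step from compound 1 to compound 2 exchanges a substituent on an aromatic carbon and is within the scatter; the step from compound 2 to compound 3 exchanges the aryl on the carbonyl carbon and is modest. Going by the values given here, no measured pair removes a whole group from the ring nitrogen, so the data give no direct anchor. With the rest of the molecule held as in compound 2, the expectation is no step beyond the scatter, a 1.2-fold lower number from compound 2 to compound 4 (0.07 log units; within the scatter), with a wide range because a group of seven heavy atoms leaves. Compound 4 is therefore expected to give 20000 nM, within 7000 nM to 60000 nM.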

Compound 4, concentration for 50% growth inhibition: > 50000 nM
Compound 4 was reported as a limit; the forecaster's own chance of this, stated with the estimate: 15%; at least 2.5-fold (0.39 log units) between middle value and limit.
By their numbers in this assay, from the lowest: compound 3; then compounds 1 and 2 (each within the scatter of the next). At a limit, above all of these: compound 4.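

Compound 4 in this assay gives > 50000 nM, which is a limit of the assay and not a number. For the compounds shown here, this is the first change at the nitrogen on the aromatic ring, and it shows that this position affects the read-out: taking off (5-methyl-1H-imidazol-4-yl)methyl gives an at least 2.1-fold higher number from compound 2 to compound 4 (0.33 log units; beyond the scatter), and taking off (1H-imidazol-4-yl)methyl gives an at least 2.7-fold higher number from compound 1 to compound 4 (0.44 log units; beyond the scatter), both beyond the scatter, whereas the methyl on the aromatic carbon of that group gave only a 1.3-fold higher number from compound 1 to compound 2 (0.11 log units; within the scatter), within the scatter. Both new steps are lower bounds, so the series shows a direction at this nitrogen but not the full size of the change: the limit of > 50000 nM in this assay, at which 1 of the 4 values shown sits.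

Still open, as far as these compounds go, is which part of the group carries this difference, that is, whether a plain methyl, a benzyl or a longer alkyl chain on this nitrogen would match the two imidazolylmethyl groups or stay with the free amino compound. Also open, from the compounds shown here alone, is whether the 3-chloro-4-fluorophenyl on the carbonyl carbon would lower the number with only hydrogen on the nitrogen, as it does with the (5-methyl-1H-imidazol-4-yl)methyl group in place.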